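This account rests on a few compounds, and the source may have more. Where it says the series, first, only, none or still open, it means among the compounds named here.

The measured compounds, each with its result in a functional assay (ileum) for inhibition, with Cavia porcellus as the target; a higher number here means a weaker inhibitor, a lower number a stronger inhibitor:
Compound 1, `CC(C)C(C)Nc1nc(O)c2cc(Cl)ccc2n1`, gives 59200 nM.
Compound 2, `Oc1nc(NCC2CCCCC2)nc2ccc(Cl)cc12`, gives 23900 nM.
Compound 3, `CC(C)C(C)Nc1nc(O)c2cc(I)ccc2n1`, gives 30400 nM.

Compound 1 and compound 3 share a core and differ at a single point: iodo in place of chloro on an aromatic carbon. That exchange gave a 1.9-fold lower number from compound 1 to compound 3 (0.29 log units; within the scatter), a step that stays within the usual scatter of repeated measurements, so on this pair alone the exchange cannot be said to have altered the inhibition at all. Compound 2 carries a different side chain; how its core differs from the core of compound 1 is not broken down here. In this assay compound 2 gives a lower number than compound 1, a gap wider than the scatter, whereas compound 2 and compound 3 lie within the scatter of each other.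

Compound 4, `Oc1nc(NCC2CCCCC2)nc2ccc(I)cc12`, is compound 2 with the very same exchange: iodo in place of chloro on an aromatic carbon. The place of the halogen is described in identical words for both pairs, so this is the same change seen once already, not merely a similar one.

For compound 4 the expected step is a 1.7-fold lower number from compound 2 to compound 4 (0.23 log units; within the scatter). Among the measured compounds shown here, this expectation rests on a 1.9-fold lower number from compound 1 to compound 3 (0.29 log units; within the scatter), the only earlier instance of the change, and since that step lay within the scatter, the new number may well prove indistinguishable from that of compound 2. Compound 4 is therefore estimated at 14000 nM, with a likely range from 6000 nM to 35000 nM.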

Compound 4, half-maximal inhibitory concentration: 26000 nM
Compound 4: the middle estimate sits 1.9-fold (0.27 log units) below what was measured, and the stated range covers the measured number.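

On the second core, iodo in place of chloro gave a 1.1-fold higher number from compound 2 to compound 4 (0.04 log units; within the scatter), so the two compounds cannot be told apart in this assay. Set beside the same exchange on the first core, the new step gives no sign that the core alters what the exchange does: the same change on two cores in this assay, a 1.9-fold lower number (0.29 log units; within the scatter) from compound 1 to compound 3 and a 1.1-fold higher number (0.04 log units; within the scatter) from compound 2 to compound 4, 2.1-fold (0.33 log units) apart, within the scatter of two such steps. This agreement is weak support for carrying the change from one core to the other, since neither step rises above the scatter: a small real effect of the exchange could be hidden on either core, and two pairs in a single assay say nothing about cores beyond these.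

The compounds shown leave open whether any other group on this aromatic carbon, such as fluoro, bromo, methyl, an amine or a carboxylic acid, would move the number in this assay by more than the scatter, since chloro and iodo are the only two groups seen there. They also leave open whether the exchange would behave in the same way with a different side chain, such as a longer chain or one ending in an amine.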